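The source may report more compounds than this note shows. Statements on the series, on what has been measured and on what is new or still open speak of the compounds shown alone.

Measured so far:
compound 1 `C=C1C(=O)OC[C@@H]1CCOC(=O)Nc1ccc(C(C)C)cc1` gives 1580 nM
compound 2 `C=C1C(=O)OC[C@@H]1CCOC(=O)Nc1ccc(CCCC)cc1` gives 1230 nM
compound 3 `C=C1C(=O)OC[C@H]1CCOC(=O)Nc1ccc(CCCC)cc1` gives 620 nM

All three were tested in a functional assay on RAW264.7 cells (Mus musculus) for inhibition, with a stated time of 30 min; a lower number here means a stronger inhibitor, a higher number a weaker inhibitor. Compound 2 and compound 1 differ by isopropyl in place of butyl on an aromatic carbon, and the step of a 1.3-fold higher number from compound 2 to compound 1 (0.11 log units; within the scatter) is seen. Compound 3 and compound 2 differ by the two compounds have the same atoms and bonds and differ only in configuration as drawn: 1 of 1 stereo elements differ; a stereocentre at a saturated ring carbon is drawn R in compound 2 and S in compound 3, and the step of a 2.0-fold lower number from compound 2 to compound 3 (0.30 log units; within the scatter) is seen; the fact that compounds 2 and 3 differ only in the configuration as drawn is all that separates this pair. Compound 4 `C=C1C(=O)OC[C@H]1CCOC(=O)Nc1ccc(C(C)C)cc1` is not yet measured. It relates to compound 3 as compound 1 relates to compound 2: isopropyl in place of butyl on an aromatic carbon, the same change at the same place. Because compound 3 gives 620 nM and the earlier step was a 1.3-fold higher number from compound 2 to compound 1 (0.11 log units; within the scatter), compound 4 is expected to move by about a 1.3-fold higher number from compound 3 to compound 4 (0.11 log units; within the scatter) in this assay. The estimate for compound 4 is 800 nM, expected to lie between 400 nM and 1600 nM.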

Compound 4, half-maximal inhibitory concentration: 340 nM
The estimate for compound 4 lay 2.4-fold (0.37 log units) above the measured number, outside the stated range (below it).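

In this assay, isopropyl in place of butyl gives a 1.8-fold lower number from compound 3 to compound 4 (0.26 log units; within the scatter), and this agrees with the earlier step on the other core: the same change on two cores in this assay, a 1.3-fold higher number (0.11 log units; within the scatter) from compound 2 to compound 1 and a 1.8-fold lower number (0.26 log units; within the scatter) from compound 3 to compound 4, 2.3-fold (0.37 log units) apart, within the scatter of two such steps. For the compounds shown here, the only step here beyond the scatter is a 4.6-fold lower number from compound 1 to compound 4 (0.67 log units; beyond the scatter), and it comes with a change in drawn configuration, not in the chain: the fact that compounds 1 and 4 differ only in the configuration as drawn. So the swap behaves alike on these two cores as far as can be read, but two small steps do not show that either chain is better, nor that the match would hold on any other core.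

Still open, going by these compounds, is how a longer chain such as hexyl, or an amine or a carboxylic acid, would read on that aromatic carbon in this assay.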